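A few compounds are considered here, and "the series" means these few. Any claim that something is new, unique, unknown or untested is made for them only; others in the source may bear on it.

Going by the values given here, in a functional assay on HUVEC cells (Homo sapiens) for inhibition (on this read-out lower numbers stand for stronger inhibition and higher numbers for weaker inhibition), compound 1 (`COc1cc(/C=C/C(=O)c2cccc(NC(=O)c3cccs3)c2)ccc1O`) gives 0.38 ug/mL and compound 2 (`COc1cc(/C=C/C(=O)c2cccc(NC(=O)c3ccco3)c2)ccc1O`) gives 0.38 ug/mL as well, so compound 2 stands level with compound 1, its only measured neighbour. Compound 3 (`CCCC(=O)Nc1cccc(C(=O)/C=C/c2ccc(O)c(OC)c2)c1`) is not yet measured. Among the compounds with values here, it differs from compound 2 by propyl in place of furan-2-yl on a carbonyl carbon as its single change, propyl in place of furan-2-yl on a carbonyl carbon. Within the data shown here, only one measured step bears on this. The step of no change at the digits printed from compound 1 to compound 2 (within the scatter) kept a ring on the carbonyl carbon, whereas propyl brings no ring, so it offers only weak guidance. Among the measured compounds shown here, no measured pair tests the loss of the ring. A small move towards weaker inhibition in this assay is therefore expected, not far beyond the scatter. The estimated step is a 1.6-fold higher number from compound 2 to compound 3 (0.20 log units; within the scatter) on this reasoning. For compound 3 the expected value is 0.6 ug/mL within an estimated range from 0.2 ug/mL to 1.8 ug/mL for now.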

Compound 3, half-maximal inhibitory concentration: 1.27 ug/mL
Compound 3: the middle estimate sits 2.1-fold (0.33 log units) below what was measured, within the range that was stated.
By their numbers in this assay, from the lowest: compounds 1 and 2 (each within the scatter of the next); then compound 3.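

At the carbonyl carbon bound to the amide-type nitrogen, the read-out in this assay does respond to the group carried, with propyl giving a 3.3-fold higher number from compound 2 to compound 3 (0.52 log units; beyond the scatter) and also a 3.3-fold higher number from compound 1 to compound 3 (0.52 log units; beyond the scatter) while furan-2-yl and thiophen-2-yl stand level. The position therefore accepts one aromatic ring in place of the other, but inhibition weakens modestly when the ring is lost. Nothing available explains this step.

Propyl differs from furan-2-yl both in carrying no ring and in having fewer heavy atoms, and the compounds shown do not separate these two differences. A saturated ring such as cyclopentyl or a longer chain such as pentyl on the same carbonyl carbon would help to tell them apart.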